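The source may report more compounds than this note shows. Statements on the series, on what has been measured and on what is new or still open speak of the compounds shown alone.

Measured compounds: compound 1 `COc1cc(/C=N/Nc2nc(-c3ccc(F)c(F)c3)cs2)cc(Br)c1OC`, > 100000 nM; compound 2 `COc1cc(/C=N/Nc2nc(-c3ccc(F)c(F)c3)cs2)c(Br)c(Br)c1OC`, 54700 nM.

Among the compounds with values here, in an ADME assay on HUVEC cells (Homo sapiens) for inhibition, read by MTT assay, with a stated time of 48 h (a lower number here means a stronger inhibitor, a higher number a weaker inhibitor), compound 2 gives 54700 nM, the only number in the set. Compound 1 gives > 100000 nM, which is a limit of the assay (the limit of > 100000 nM in this assay, at which 1 of the 2 values shown sits). Within the data shown here, the one measured step, an at least 1.8-fold lower number from compound 1 to compound 2 (0.26 log units; that floor lies within the scatter), concerns bromo in place of hydrogen on an aromatic carbon, not the group that changes here. Compound 3 `COc1ccccc1-c1csc(N/N=C/c2cc(OC)c(OC)c(Br)c2Br)n1` carries 2-methoxyphenyl in place of 3,4-difluorophenyl on an aromatic carbon. Among the measured compounds shown here, no measured step bears on this change, so no shift beyond the scatter is expected in this assay. Compound 3 is expected at 55000 nM, between 18000 nM and 160000 nM. This means an expected step of a 1.0-fold higher number from compound 2 to compound 3 (0.00 log units; within the scatter).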

Compound 3, half-maximal inhibitory concentration: > 100000 nM
Compound 3 was reported as a limit; the forecaster's own chance of this, stated with the estimate: 35%; middle value at least 1.8-fold (0.25 log units) from the limit.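

Within the data shown here, at the aromatic carbon next to the ring nitrogen, the first reading of this aryl group in this assay is an at least 1.8-fold higher number from compound 2 to compound 3 (0.26 log units; that floor lies within the scatter). Compound 3 gives > 100000 nM, which is a limit and not a number. The 2-methoxyphenyl group thus shows no lower number here than 3,4-difluorophenyl, while the true size of the step stays unread, and readings in the series gather at a limit: the limit of > 100000 nM in this assay, at which 2 of the 3 values shown sit.

Still open, going by these compounds, is whether the methoxy group or the loss of both fluorines governs the step. Also open, on these data alone, is how an unsubstituted phenyl or an aminophenyl would read at this carbon.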